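The source may report more compounds than this note shows. Statements on the series, on what has been measured and on what is new or still open speak of the compounds shown alone.

Of the compounds shown here, three of the shared core have been measured in a functional assay on HCT-116 cells (Homo sapiens) for antiproliferative activity, read by MTT assay; on this read-out lower numbers stand for stronger inhibition and higher numbers for weaker inhibition. Compound 1 `Cc1cccc(/C=N/Nc2ncc3c(n2)n(C2CCCC2)c(=O)c(=O)n3C)c1` stops at the limit > 100000 nM, which is a limit and not a number. Compound 2 `Cn1c(=O)c(=O)n(C2CCCC2)c2nc(N/N=C/c3ccc(F)c(Cl)c3)ncc21` gives 9020 nM. Compound 3 `COc1ccc(/C=N/Nc2ncc3c(n2)n(C2CCCC2)c(=O)c(=O)n3C)c(OC)c1` likewise stops at the limit > 100000 nM, again a limit and not a number. Its standing is thus known only as a limit (the limit of > 100000 nM in this assay, at which 2 of the 3 values shown sit). Compound 4 `Cn1c(=O)c(=O)n(C2CCCC2)c2nc(N/N=C/c3cc([N+](=O)[O-])ccc3Cl)ncc21` has not yet been measured; it differs from compound 3 in that (2-chloro-5-nitrophenyl in place of 2,4-dimethoxyphenyl on a carbon with a double bond to nitrogen). The step that bears on this is an at least 11-fold higher number from compound 2 to compound 3 (1.04 log units; beyond the scatter), a large move away from a halogenated phenyl, while a step that the two limits leave unreadable from compound 1 to compound 3 and an at least 11-fold lower number from compound 1 to compound 2 (1.04 log units; beyond the scatter) set the methyl analogue at the limit. Returning to a chlorinated phenyl, compound 4 is expected to reach a readable number, with a step of an at least 5.0-fold lower number from compound 3 to compound 4 (0.69 log units; beyond the scatter). The estimate for compound 4 is 20000 nM, within 5000 nM to 100000 nM.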

Compound 4, half-maximal inhibitory concentration: 5610 nM
For compound 4 the middle estimate is 3.6-fold (0.55 log units) above the measured one; the measured number falls inside the stated range.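

In this assay, 2-chloro-5-nitrophenyl on the carbon with a double bond to nitrogen gives a readable value, with an at least 17-fold lower number from compound 3 to compound 4 (1.25 log units; beyond the scatter) and an at least 17-fold lower number from compound 1 to compound 4 (1.25 log units; beyond the scatter); both steps start from a limit and not a number: the limit of > 100000 nM in this assay, at which 2 of the 4 values shown sit.

With a 1.6-fold lower number from compound 2 to compound 4 (0.21 log units; within the scatter), 2-chloro-5-nitrophenyl and 3-chloro-4-fluorophenyl cannot be told apart. Among these four compounds, only the two phenyl groups carrying chlorine give readable values.

As far as these compounds go, whether the chlorine itself matters remains open, since no phenyl group here carries a nitro group without chlorine. Also open, from the compounds shown here alone, is how a phenyl group bearing an amine or a carboxylic acid would behave at this place.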